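A few compounds are considered here, and "the series" means these few. Any claim that something is new, unique, unknown or untested is made for them only; others in the source may bear on it.

Measured compounds:
Compound 1 `Cc1c(C)c2c(c(C)c1O)CCC(C)(COc1ccc(/C=C3\SC(=O)N(C)C3=O)cc1)O2` — 127%
Compound 2 `Cc1c(C)c2c(c(C)c1OC(=O)CCCCCCCNC(=O)OC(C)(C)C)CCC(C)(COc1ccc(/C=C3\SC(=O)NC3=O)cc1)O2` — 74.7%
Compound 3 `Cc1c(C)c2c(c(C)c1CCCCCCNC(=O)OCc1ccccc1)CCC(C)(COc1ccc(/C=C3\SC(=O)NC3=O)cc1)O2` — 80.3%

In an ADME assay on cells (Hepatocyte, Homo sapiens) for cytotoxicity, read by MTT assay, with a stated time of 90 min, tested at 200 uM (on this read-out higher numbers stand for a weaker effect at the one concentration tested and lower numbers for a stronger effect), compound 1 gives 127%, the highest of the three numbers. Compound 3 gives 80.3% and compound 2 gives 74.7%; both lie beyond the scatter below compound 1, whereas compound 2 and compound 3 sit within the scatter of each other and cannot be ordered.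

The step under review leads from compound 1 to compound 4 `Cc1c(C)c2c(c(C)c1CCCCCCN)CCC(C)(COc1ccc(/C=C3\SC(=O)N(C)C3=O)cc1)O2`, a compound not yet measured in this assay. The difference between the two structures is 6-aminohexyl in place of hydroxy on an aromatic carbon

Among the measured compounds shown here, no measured pair shares exactly this change, so its size can only be guessed from compound 2 and compound 3, whose structures also lack the hydroxy of compound 1. Compound 2 gives 74.7% and compound 3 gives 80.3%, both well below compound 1. On that basis a step downward, beyond the scatter, is expected from compound 1 to compound 4, of about a number 47 percentage points lower from compound 1 to compound 4 (beyond the scatter). Compound 4 is therefore estimated at 80%, within a range from 50% to 115%.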

Compound 4, a percentage reported as activity, at one concentration (the size of the read-out at that concentration, not a potency): 82.7%
Compound 4: the middle estimate sits 2.7 percentage points below what was measured; the range from low to high includes it.
By their numbers in this assay, from the lowest: compounds 2, 3 and 4 (each within the scatter of the next); then compound 1.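

With the rest of compound 1 unchanged, putting 6-aminohexyl in place of hydroxy on the aromatic carbon gives, in this assay, a number 44.3 percentage points lower from compound 1 to compound 4 (beyond the scatter) and counts as a large step. Among the compounds shown here, it is the first step at this position that can be read on its own, since compound 2 and compound 3 differ from compound 1 in more than one place. Nothing among the available data accounts for the size of this step.

For the compounds shown here, the single step cannot separate the loss of the hydroxy from the arrival of the 6-aminohexyl chain. It also leaves open what a methyl group, a shorter or longer chain, or a carboxylic acid in place of the amine would give at this position.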